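Swapping Methyl for Cyclobutyl on an Amine Nitrogen

The source may report more compounds than this note shows. Statements on the series, on what has been measured and on what is new or still open speak of the compounds shown alone.

- compound 1 `CCCN(Cc1ccc(OCCN2C(=O)CCC2=O)c(C)c1)C1c2ccc(Cl)cc2CC1C(=O)O` gives 3000000 nM
- compound 2 `Cc1cc(CN(CCC(F)(F)F)C(CC(=O)O)c2ccc(Cl)cc2)ccc1OCCN1C(=O)CCC1=O` gives 3000000 nM
- compound 3 `Cc1cc(CN(C)C(CC(=O)O)c2ccc(Cl)cc2)ccc1OCCn1c(=O)ccn(C)c1=O` gives 3000000 nM

These three values all come from a physicochemical assay for solubility, at pH 1.1; a higher number here means a more soluble compound, a lower number a less soluble compound. The reported numbers are the same, so compound 3 stands level with the other two, and nothing separates them beyond the usual scatter of repeated measurements.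

The next molecule, compound 4 `Cc1cc(CN(C2CCC2)C(CC(=O)O)c2ccc(Cl)cc2)ccc1OCCn1c(=O)ccn(C)c1=O`, is built from compound 3 by a single edit: cyclobutyl in place of methyl on an amine nitrogen. In words, cyclobutyl sits in place of methyl on an amine nitrogen, and the rest of the structure stays the same.

For the measured compounds named here, no two measured compounds differ in just one place, so this kind of edit has not been tested on its own in this assay. The best available guide is indirect. Compound 1, at 3000000 nM, and compound 2, at 3000000 nM, both carry something other than methyl on an amine nitrogen, and both still match compound 3. Three compounds make a thin basis, but they point to no shift in either direction beyond the scatter.

The expected result is no change at the digits printed from compound 3 to compound 4 (within the scatter), an estimated step that stays within the scatter. The estimated value for compound 4 is 3000000 nM, with an expected range from 1200000 nM to 3000000 nM.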

Compound 4, solubility: 3000000 nM
Beside the measured number, compound 4's estimate shows no gap at the digits printed; low and high end bracket the measured number.
By their numbers in this assay, from the lowest: compounds 1, 2, 3 and 4 (each within the scatter of the next).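

In this assay, the first direct test of this position gives no change at the digits printed from compound 3 to compound 4 (within the scatter), even though cyclobutyl brings 4 heavy atoms and one four-membered non-aromatic ring of carbon only, where methyl brought 1 heavy atom. On this amine nitrogen, whose other neighbours are a saturated chain carbon on each side, the reading therefore does not tell the two groups apart, and the printed number of compound 3 is shared by compound 4 at 3000000 nM in this single pair. Nothing measured here offers an explanation for this result.

For the compounds shown here, only this one swap can be read at this position, so it remains open whether a group of another kind on the same nitrogen, such as a chain ending in an amine or a carboxylic acid, would give a different reading. Going by these compounds alone, it is also open whether the same exchange of methyl for cyclobutyl would read alike on a different core, such as the one carried by compound 1.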